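Amide in place of sulfonamide: compound 2 to compound 3

The compounds below may be only part of what the source reports. "The series", "measured", "known", "first", "only" and "open" are said of these compounds alone.

Of the compounds shown here, two have been measured in an assay on blood for inhibition of Indoleamine 2,3-dioxygenase 1 (Homo sapiens), read by mass spectrometry, with stated times of 4 h and 18 h; on this read-out higher numbers stand for weaker inhibition and lower numbers for stronger inhibition. Compound 1 `COc1ncc(NC(=O)[C@H](C)[C@H]2CC[C@@H](c3ccnc4ccc(F)cc43)CC2)cn1` gives 80 nM. Compound 2 `C[C@@H](NS(=O)(=O)c1ccc(Cl)cc1)[C@H]1CC[C@@H](c2ccnc3ccc(F)cc32)CC1` gives 484 nM, the higher of the two numbers, so it inhibits less strongly than compound 1. Compound 3 `C[C@@H](NC(=O)c1ccccc1Cl)[C@H]1CC[C@@H](c2ccnc3ccc(F)cc32)CC1` is not yet measured; it differs from compound 2 in one place: (2-chlorophenyl)carbonyl in place of (4-chlorophenyl)sulfonyl on an amine nitrogen. For the measured compounds named here, no measured pair isolates this exchange, but compound 1, at 80 nM, also bears a carbonyl rather than a sulfonyl on its nitrogen. A move towards stronger inhibition is therefore expected, of the size a 2.4-fold lower number from compound 2 to compound 3 (0.38 log units; beyond the scatter). Compound 3 is estimated to give 200 nM, between 60 nM and 700 nM.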

Compound 3, half-maximal inhibitory concentration: 135 nM
The estimate for compound 3 lay 1.5-fold (0.17 log units) above the measured number, within the range that was stated.
By their numbers in this assay, from the lowest: compounds 1 and 3 (each within the scatter of the next); then compound 2.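

In this assay the amine nitrogen accepts (2-chlorophenyl)carbonyl in place of (4-chlorophenyl)sulfonyl, and this first direct pair at the position gives stronger inhibition, with a 3.6-fold lower number from compound 2 to compound 3 (0.55 log units; beyond the scatter). The exchange moves the chlorine's place on the ring and replaces the sulfonyl with a carbonyl in a single step. No measurement at hand explains the gain.

The step does not show how much of the gain belongs to each of those two changes. A (4-chlorophenyl)carbonyl group or a (2-chlorophenyl)sulfonyl group on the same nitrogen would separate them.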